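Compound 3 to compound 4: new group on the carbonyl carbon

The compounds below may be only part of what the source reports. "The series", "measured", "known", "first", "only" and "open" are said of these compounds alone.

Values in a functional assay on MDA-MB-231 cells (Homo sapiens) for antiproliferative activity, read by MTT assay, with a stated time of 72 h (a lower number here means a stronger inhibitor, a higher number a weaker inhibitor), so far:
- compound 1 `CC(=O)O[C@H]1CC[C@]2(C)[C@H](CC[C@@](C)(O)[C@H]2CC[C@@H]2C(C)=CC[C@@H]3C(C)=CC[C@@H]3C2(C)C)OC1(C)C` gives 39200 nM
- compound 2 `CC1=CC[C@H]2[C@H](CC[C@]2(C)O)C(C)(C)[C@@H]1CC[C@H]1[C@]2(C)CC[C@H](OC(=O)NCc3ccccc3)C(C)(C)O[C@H]2CC[C@@]1(C)O` gives 40300 nM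
- compound 3 `CC1=CC[C@H]2[C@H](CC[C@]2(C)O)C(C)(C)[C@@H]1CC[C@H]1[C@]2(C)CC[C@H](OC(=O)NS(=O)(=O)c3ccc(C)cc3)C(C)(C)O[C@H]2CC[C@@]1(C)O` gives 47100 nM

All three values lie within the scatter of one another, so compound 3 cannot be separated from compound 1 or compound 2. The next structure, compound 4 `CC1=CC[C@H]2[C@H](CC[C@]2(C)O)C(C)(C)[C@@H]1CC[C@H]1[C@]2(C)CC[C@H](OC(=O)c3ccccc3Cl)C(C)(C)O[C@H]2CC[C@@]1(C)O`, has 2-chlorophenyl in place of ((4-methylphenyl)sulfonyl)amino on a carbonyl carbon, counted as 2-chlorophenyl in place of ((4-methylphenyl)sulfonyl)amino on a carbonyl carbon for the exchange.

Going by the values given here, one measured step bears on this change, a 1.2-fold higher number from compound 2 to compound 3 (0.07 log units; within the scatter) for a swap on the amide-type nitrogen. Among the compounds with values here, that step stays within the scatter, but no measured step replaces the group directly on the carbonyl carbon, so the support is indirect. No step beyond the scatter is expected in this assay and no firm direction can be argued. The expected change is a 1.6-fold lower number from compound 3 to compound 4 (0.20 log units; within the scatter) and this estimated shift is not beyond the scatter. The estimate for compound 4 is 30000 nM with an expected range from 12000 nM to 55000 nM overall.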

Compound 4, half-maximal inhibitory concentration: 24300 nM
For compound 4 the middle estimate is 1.2-fold (0.09 log units) above the measured one, within the range that was stated.
By their numbers in this assay, from the lowest: compounds 4, 1, 2 and 3 (each within the scatter of the next).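

In this assay, this exchange places an aryl group directly on the carbonyl carbon, with no nitrogen in the linkage, and the two readings are a 1.9-fold lower number from compound 3 to compound 4 (0.29 log units; within the scatter) and a 1.7-fold lower number from compound 2 to compound 4 (0.22 log units; within the scatter). Compound 4 therefore cannot be separated from compound 2 or compound 3, so the nitrogen and its hydrogen-bond donor are not shown to matter at this position in this assay. No measured evidence accounts for these values.

Going by these compounds, whether any group on this carbonyl carbon can produce a step beyond the scatter remains open. On these data alone, the role of the chlorine in 2-chlorophenyl also remains open, and unsubstituted phenyl, a phenyl ring bearing a carboxylic acid or an amine, or a longer alkyl chain would each test this position further.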